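The compounds below may be only part of what the source reports. "The series", "measured", "known", "first", "only" and "open" are said of these compounds alone.

Measured so far in an ADME assay on Huh-7 cells (Homo sapiens) for cytotoxicity, with a stated time of 72 h; a higher number here means that more compound is tolerated, a lower number that less compound is tolerated:
- compound 1 `CCCS(=O)(=O)Nc1ccc2c(c1)S(=O)(=O)N=C(c1c(O)c(-c3cccs3)nn(CCC(C)C)c1=O)N2`: > 1000 nM (a limit)
- compound 2 `CC(C)CCn1nc(CC2CCC2)c(O)c(C2=NS(=O)(=O)c3cc(NS(C)(=O)=O)ccc3N2)c1=O`: > 33000 nM (a limit)

Neither compound has a number, so no order can be read between them. Compound 2 stands only at its limit, (the limit of > 33000 nM in this assay, at which 1 of the 2 values shown sits).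

Compound 3 `CC(C)CCn1nc(CCC(F)(F)F)c(O)c(C2=NS(=O)(=O)c3cc(NS(C)(=O)=O)ccc3N2)c1=O` differs from compound 2 in one place: 2,2,2-trifluoroethyl in place of cyclobutyl on a saturated chain carbon bound to an aromatic carbon. Cut one bond further out, the same difference reads cyclobutylmethyl to 3,3,3-trifluoropropyl.

Among the measured compounds shown here, no measured pair shows this change or any other single change, so the expectation rests only on compound 2 and its limit of > 33000 nM. The expected step in this assay, a number no higher from compound 2 to compound 3 (the limit leaves the size open), is none beyond the scatter, in neither direction. A reading reported only as a limit is also expected to be likely. For compound 3 the estimate is 33000 nM, with an expected range of 12000 nM to 70000 nM.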

Compound 3, half-maximal cytotoxic concentration: > 33000 nM
Compound 3: only a limit was reported (the forecaster's own chance of this, stated with the estimate: 75%); the middle value sits exactly at the limit.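

In this assay compound 2 and compound 3 are both reported only as limits, so no step can be read between them. Still open, as far as these compounds go, is where either compound's half-maximal cytotoxic concentration lies, and whether replacing cyclobutyl with 2,2,2-trifluoroethyl changes it at all.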